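Azetidinone series: pyridyl swap on the saturated ring carbon

The compounds below may be only part of what the source reports. "The series", "measured", "known", "first", "only" and "open" are said of these compounds alone.

Measured so far, in a functional assay on IMR-32 cells (Homo sapiens) for cytotoxicity; on this read-out lower numbers stand for stronger inhibition and higher numbers for weaker inhibition:
- compound 1, `COc1ccc(C2C(OC(C)=O)C(=O)N2c2cc(OC)c(OC)c(OC)c2)cc1`: 251 nM
- compound 2, `COc1ccc(C2C(OC(C)=O)C(=O)N2c2cc(OC)c(OC)c(OC)c2)cc1N`: 73.1 nM
- compound 3, `COc1ccc(C2C(O)C(=O)N2c2cc(OC)c(OC)c(OC)c2)cc1N`: 37 nM; 38.3 nM (2 entries)

Compound 2 gives the lowest of the two single numbers in this assay; its nearest neighbour is compound 1, and the change a 3.4-fold lower number from compound 1 to compound 2 (0.54 log units; beyond the scatter) stands beyond the scatter. Compound 3 is recorded as the several entries of compound 3 in this assay, 37 nM; 38.3 nM (2 entries) and is given here without a computed step to compound 2.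

Compound 4, `COc1ccc(C2C(OC(C)=O)C(=O)N2c2cc(OC)c(OC)c(OC)c2)cn1`, is not yet measured. It differs from compound 2 by 6-methoxypyridin-3-yl in place of 3-amino-4-methoxyphenyl on a saturated ring carbon. For the measured compounds named here, the only measured step that bears on this change is a 3.4-fold lower number from compound 1 to compound 2 (0.54 log units; beyond the scatter), which shows the amino group on the aromatic carbon lowering the number. Going by the values given here, compound 4 has no amino group, so that gain is expected to be lost, while the ring nitrogen of the 6-methoxypyridin-3-yl group has no measured precedent. The step of a 4.1-fold higher number from compound 2 to compound 4 (0.61 log units; beyond the scatter) is therefore expected to run towards higher numbers, roughly back to the level of compound 1. Compound 4 is expected to give about 300 nM in this assay, within a range from 100 nM to 1000 nM.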

Compound 4, half-maximal inhibitory concentration: > 1000 nM
Compound 4: no number, only a limit; the forecaster's own chance of this, stated with the estimate: 5%; middle value at least 3.3-fold (0.52 log units) away from the limit.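

In this assay compound 4 carries only a limit of the assay, > 1000 nM, not a number. The earlier compounds shown here all keep an aromatic ring of carbon only on the saturated ring carbon, and here the swap of 4-methoxyphenyl for 6-methoxypyridin-3-yl, with no amino group involved, gives an at least 3.9-fold higher number from compound 1 to compound 4 (0.60 log units; beyond the scatter). Set beside the amino step, a 3.4-fold lower number from compound 1 to compound 2 (0.54 log units; beyond the scatter), the full change gives an at least 13-fold higher number from compound 2 to compound 4 (1.13 log units; beyond the scatter), so removing the amino group is not the only thing that moves the number at this position.

From the compounds shown here alone, how far either step extends past the limit stays open. Also open, going by these compounds, is whether a 6-methoxypyridin-3-yl ring carrying an amino group, a free hydroxyl in place of the acetoxy group, or a pyrimidine ring would bring the number back down.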